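From thiophen-2-yl to pyridin-3-yl on a sulfonyl sulfur

This account rests on a few compounds, and the source may have more. Where it says the series, first, only, none or still open, it means among the compounds named here.

Results so far in a functional assay on HCT-116 cells (Homo sapiens) for antiproliferative activity (on this read-out lower numbers stand for stronger inhibition and higher numbers for weaker inhibition), by compound
compound 1 (`CS(=O)(=O)N1Cc2ccc(/C=C/C(=O)NO)cc2C1`): "not determined" (no result reported)
compound 2 (`O=C(/C=C/c1ccc2c(c1)CN(S(=O)(=O)c1cccs1)C2)NO`): 800 nM

For the measured compounds named here, compound 2 gives 800 nM and is the only compound with a number. Compound 1 has no result to compare it with, so nothing yet shows whether this value is high or low for the series.

Compound 3 (`O=C(/C=C/c1ccc2c(c1)CN(S(=O)(=O)c1cccnc1)C2)NO`) keeps the shared core and changes one group, with pyridin-3-yl in place of thiophen-2-yl on a sulfonyl sulfur. A six-membered aromatic ring thus replaces a five-membered one, and each carries one hetero atom.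

Going by the values given here, no measured pair of compounds shows how this assay responds to a change at this place. The expectation rests on compound 2 alone at 800 nM and must stay wide. A small step towards weaker inhibition is expected, possibly no larger than the usual scatter. The estimated change is a 1.3-fold higher number from compound 2 to compound 3 (0.10 log units; within the scatter) on this reasoning. Compound 3 is estimated at 1000 nM with an expected range from 350 nM to 3000 nM in this measurement.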

Compound 3, half-maximal inhibitory concentration: 4260 nM
Compound 3: the middle estimate sits 4.3-fold (0.63 log units) below what was measured; the whole stated range lies below it.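

In this assay, for the compounds shown here, the swap of thiophen-2-yl for pyridin-3-yl gives a 5.3-fold higher number from compound 2 to compound 3 (0.73 log units; beyond the scatter) and is the first measured pair to show that the read-out responds to the group on the sulfonyl sulfur. The two groups have the same counts of hetero atoms and hydrogen-bond acceptors, and neither carries a net charge, so these counts alone do not predict the outcome for this pair. They differ in ring size and in the hetero atom, sulfur in thiophen-2-yl and nitrogen in pyridin-3-yl, but no measurement here bears on why the number rises.

This single pair cannot separate the effect of ring size from that of the identity of the hetero atom, and it cannot show whether other groups on the sulfonyl sulfur would follow the same direction. A phenyl ring, which is six-membered with no hetero atom, would help to pull those two differences apart, while a pyridine ring joined through another carbon could show whether the placement of the nitrogen matters.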